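The compounds below may be only part of what the source reports. "The series", "measured", "known", "first", "only" and "open" are said of these compounds alone.

Measured so far in an ADME assay on Vero cells (Chlorocebus sabaeus) for cytotoxicity, read by crystal violet staining; a lower number here means that less compound is tolerated, a higher number that more compound is tolerated:
- compound 1, `Brc1cccc(/N=N/N2CCCCC2)c1`: 85000 nM
- compound 2, `CN(/N=N/c1ccccc1)c1ccccc1`: 50000 nM
- compound 3, `FC(F)(F)c1cccc(/N=N/N2CCCC2)c1`: > 100000 nM

In this assay compound 3 gives only a limit, not a number, at the limit of > 100000 nM in this assay, at which 1 of the 3 values shown sits. Among the two numbers that remain, compound 2 has the lower one in this assay, but compound 1 sits within the scatter of it, so the two are not told apart by these data. Within the data shown here, no pair of measured compounds differs in a single place, so no measured step is available to lean on.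

Compound 4, `Cc1ccc(/N=N/N(C)c2ccccc2)cc1`, is not yet measured in this assay. It differs from compound 2 by methyl in place of hydrogen on an aromatic carbon. Among the measured compounds shown here, nothing among the measured compounds reports the effect of such a change, and a single methyl is a small addition; no step beyond the scatter is expected in either direction, with the outcome as likely to sit a little higher as a little lower.

For compound 4 in this assay the estimate is 60000 nM, within 30000 nM to 120000 nM, which is expected to mean a step of a 1.2-fold higher number from compound 2 to compound 4 (0.08 log units; within the scatter), within the scatter.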

Compound 4, half-maximal cytotoxic concentration: 58000 nM
Estimate against measurement, compound 4: 1.0-fold (0.01 log units) above; low and high end bracket the measured number.
By their numbers in this assay, from the lowest: compounds 2, 4 and 1 (each within the scatter of the next). At a limit, above all of these: compound 3.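

In this assay, among these compounds, the exchange of hydrogen for methyl on an aromatic carbon, para to a large group, gives a 1.2-fold higher number from compound 2 to compound 4 (0.06 log units; within the scatter) and provides the first single-place step. This position therefore carries one added carbon without a difference that these data can separate from the scatter, so compound 2 and compound 4 are not told apart in this assay. No evidence shown bears on the size of this step, and it rests on one pair of compounds only.

Going by these compounds, whether a longer chain, an amine or a carboxylic acid at the same position would give a step beyond the scatter remains open, as does the outcome of placing methyl on another aromatic carbon. Also open, on these data alone, is whether the same exchange of hydrogen for methyl would give a similar result on the core of compound 1 or the core of compound 3, since neither compound is joined to another by a single-place step.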